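Methylsulfonyl to Sulfamoyl on a Shared Core

A few compounds are considered here, and "the series" means these few. Any claim that something is new, unique, unknown or untested is made for them only; others in the source may bear on it.

Measured so far in an assay on RBL-1 cells with Polyunsaturated fatty acid 5-lipoxygenase (Rattus norvegicus) as the target; on this read-out higher numbers stand for weaker inhibition and lower numbers for stronger inhibition:
compound 1 `CC(=O)c1cc(Cc2ccccc2)c(O)c2ccccc12` gives 510 nM
compound 2 `CS(=O)(=O)c1cc(Cc2ccccc2)c(O)c2ccccc12` gives 40000 nM

Compound 2 stands at the higher of the two measured numbers, the step being a 78-fold higher number from compound 1 to compound 2 (1.89 log units; beyond the scatter). Compound 3 `NS(=O)(=O)c1cc(Cc2ccccc2)c(O)c2ccccc12` differs from compound 2 by amino in place of methyl on a sulfonyl sulfur. Among the measured compounds shown here, no measured step concerns this change: the only step available, from acetyl to methylsulfonyl, does not touch the substituent on the sulfonyl sulfur. Compound 3 is therefore expected to stay close to compound 2, with an estimated step of a 1.6-fold lower number from compound 2 to compound 3 (0.20 log units; within the scatter) that remains within the scatter. The value of compound 3 is estimated at 25000 nM, in a range from 5000 nM to 120000 nM.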

Compound 3, half-maximal inhibitory concentration: 9400 nM
Beside the measured number, compound 3's estimate is 2.7-fold (0.42 log units) above it; the measured number falls inside the stated range.
By their numbers in this assay, from the lowest: compound 1; then compound 3; then compound 2.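

In this assay, the substituent on the sulfonyl sulfur proves to matter: amino in place of methyl gives a 4.3-fold lower number from compound 2 to compound 3 (0.63 log units; beyond the scatter). Sulfamoyl still does not match acetyl on the aromatic carbon, with an 18-fold higher number from compound 1 to compound 3 (1.27 log units; beyond the scatter), so this change recovers only part of the loss seen with methylsulfonyl. No evidence is available that bears on why these numbers differ.

The compounds shown leave open whether methylamino or dimethylamino on the sulfonyl sulfur would lower the number further. They also leave open how a carboxylic acid or a longer acyl chain in place of acetyl would compare.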